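Fluorophenyl and Trifluoromethylphenyl Amides in a Cytotoxicity Assay

The source may hold more compounds than are shown below. What is called first, only, known or untested is meant among the compounds shown, and "the series" means these compounds.

Two compounds share a core bearing two nitro-substituted trifluoromethylphenyl groups and an aroyl amide. Compound 1 `O=C(c1ccccc1F)N(/N=N/c1ccc([N+](=O)[O-])cc1C(F)(F)F)c1ccc([N+](=O)[O-])cc1C(F)(F)F` carries a 2-fluorophenyl on the carbonyl carbon, and in a functional assay on HeLa cells (Homo sapiens) for cytotoxicity, read by MTT assay, with a stated time of 72 h (a higher number here means a weaker inhibitor, a lower number a stronger inhibitor), compound 1 gives 800 nM. Compound 2 `O=C(c1cccc(C(F)(F)F)c1)N(/N=N/c1ccc([N+](=O)[O-])cc1C(F)(F)F)c1ccc([N+](=O)[O-])cc1C(F)(F)F` carries a 3-(trifluoromethyl)phenyl there instead, and in this assay compound 2 gives 750 nM. The two numbers stand within the scatter of each other, as the step of a 1.1-fold lower number from compound 1 to compound 2 (0.03 log units; within the scatter) shows, so neither compound can be called the stronger.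

Compound 3 `O=C(c1ccc(F)cc1)N(/N=N/c1ccc([N+](=O)[O-])cc1C(F)(F)F)c1ccc([N+](=O)[O-])cc1C(F)(F)F` has not been measured. It differs from compound 2 in one place: 4-fluorophenyl in place of 3-(trifluoromethyl)phenyl on a carbonyl carbon. Going by the values given here, the only step that bears on it is the exchange of one aryl group for another on that same carbonyl carbon, a 1.1-fold lower number from compound 1 to compound 2 (0.03 log units; within the scatter), which left the number essentially unchanged. On that basis compound 3 is expected to give a step of a 1.1-fold higher number from compound 2 to compound 3 (0.03 log units; within the scatter), that is, none beyond the scatter. The estimate for compound 3 in this assay is therefore 800 nM, with a range from 400 nM to 1600 nM.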

Compound 3, half-maximal inhibitory concentration: 1000 nM
The estimate for compound 3 lay 1.3-fold (0.10 log units) below the measured number, within the range that was stated.
By their numbers in this assay, from the lowest: compounds 2, 1 and 3 (each within the scatter of the next).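

With compound 3, three aryl groups have now stood on the carbonyl carbon whose other neighbour is the amide-type nitrogen: in this assay the change from 3-(trifluoromethyl)phenyl to 4-fluorophenyl gives a 1.3-fold higher number from compound 2 to compound 3 (0.12 log units; within the scatter) and the change from 2-fluorophenyl to 4-fluorophenyl gives a 1.3-fold higher number from compound 1 to compound 3 (0.10 log units; within the scatter) across these two exchanges. The earlier pair had shown only that 2-fluorophenyl and 3-(trifluoromethyl)phenyl could not be told apart, whereas the new compound extends this to a third group and to two further exchanges, so that all three aryl groups now read alike at this position within the scatter. Nothing measured here speaks to why these groups read alike.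

All three groups are fluorine-bearing phenyl rings, so the compounds shown leave open whether a phenyl ring carrying an amine or a carboxylic acid, or a longer alkyl chain in place of the ring, would give a step beyond the scatter. They also leave open whether the two nitro-substituted trifluoromethylphenyl groups of the shared core can be exchanged as freely as the aryl group on the carbonyl carbon.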